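Aryl acetal variation in a thromboxane synthase series

The source may report more compounds than this note shows. Statements on the series, on what has been measured and on what is new or still open speak of the compounds shown alone.

Measured compounds:
compound 1, `O=C(O)CC/C=C\CC1COC(c2ccccc2Cl)OC1c1cccnc1`: 48 nM
compound 2, `N#Cc1ccccc1C1OCC(C/C=C\CCC(=O)O)C(c2cccnc2)O1`: 54 nM
compound 3, `Cc1ccc(C#N)c(OC(C)(C)C2OCC(C/C=C\CCC(=O)O)C(c3cccnc3)O2)c1`: 50 nM

All three share one core and differ only in the aryl group on the acetal. In an assay for inhibition of Thromboxane-A synthase (Homo sapiens), using microsomes (on this read-out higher numbers stand for weaker inhibition and lower numbers for stronger inhibition), compound 1 gives 48 nM, compound 2 gives 54 nM and compound 3 gives 50 nM. Compound 3 thus sits in the same narrow band as compound 1 and compound 2; the gaps to both are within the scatter, so no order among the three can be read from these numbers.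

The next compound, compound 4, `COc1ccccc1OC(C)(C)C1OCC(C/C=C\CCC(=O)O)C(c2cccnc2)O1`, differs from compound 3 by 2-methoxyphenyl in place of 2-cyano-5-methylphenyl on an oxygen on a saturated carbon. Among the compounds with values here, only one measured step touches the aryl group: a 1.1-fold higher number from compound 1 to compound 2 (0.05 log units; within the scatter), which shows that exchanging one aromatic substituent for another left the number unchanged within the scatter. Within the data shown here, the change from compound 3 to compound 4 is broader, since the nitrile is lost and a methoxy group enters, and no measured pair covers that. On the evidence of compound 1 and compound 2, no step beyond the scatter is expected in this assay, with a wide range to allow for the untested exchange.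

For compound 4 the estimate is 60 nM, with a range from 25 nM to 150 nM. That estimate means a step of a 1.2-fold higher number from compound 3 to compound 4 (0.08 log units; within the scatter), expected to stay within the scatter.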

Compound 4, half-maximal inhibitory concentration: 60 nM
Estimate against measurement, compound 4: no gap at the digits printed; the measured number falls inside the stated range.
By their numbers in this assay, from the lowest: compounds 1, 3, 2 and 4 (each within the scatter of the next).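

In this assay, exchanging the whole 2-cyano-5-methylphenyl group for 2-methoxyphenyl on an oxygen on a saturated carbon gives a 1.2-fold higher number from compound 3 to compound 4 (0.08 log units; within the scatter). The earlier compounds shown here showed only one substituent exchanged for another on an aromatic carbon; here the nitrile and the methyl group leave together and a methoxy group enters, and the step still stays within the scatter. At this position, then, a nitrile is not needed for a number in the band of compound 3, although the result covers only these two aryl groups, and no measurement on hand accounts for this.

The compounds shown leave open whether any group on this aryl ring moves the number beyond the scatter, since every aryl group here carries a nitrile, a chloro or a methoxy group, and an amine or a longer alkoxy chain on the ring would test this. They also leave open whether the aromatic ring itself matters on this oxygen, which a saturated cyclohexyl group in place of 2-methoxyphenyl would address.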